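The source may hold more compounds than are shown below. What is called first, only, known or untested is meant among the compounds shown, and "the series" means these compounds.

Measured so far:
- compound 1, `O=c1ccoc2cc(OCc3cn(Cc4ccc([N+](=O)[O-])cc4)nn3)ccc12`: 19300 nM
- compound 2, `O=c1ccoc2cc(OCc3cn(Cc4ccccc4Br)nn3)ccc12`: > 100000 nM

In a functional assay on SW480 cells (Homo sapiens) for cytotoxicity, read by MTT assay, with a stated time of 48 h (a lower number here means a stronger inhibitor, a higher number a weaker inhibitor), compound 1 gives 19300 nM. Compound 2 gives > 100000 nM, which is a limit of this assay and not a number, the one described as the limit of > 100000 nM in this assay, at which 1 of the 2 values shown sits. For the measured compounds named here, the only measured step, an at least 5.1-fold higher number from compound 1 to compound 2 (0.71 log units; beyond the scatter), is therefore itself only a lower bound.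

Compound 3, `O=c1ccoc2cc(OCc3cn(Cc4ccc(Cl)cc4)nn3)ccc12`, awaits measurement. It differs from compound 2 by 4-chlorophenyl in place of 2-bromophenyl on a saturated chain carbon bound to an aromatic nitrogen. The step that bears on this change is an at least 5.1-fold higher number from compound 1 to compound 2 (0.71 log units; beyond the scatter), where a 4-nitrophenyl gave way to a 2-bromophenyl and the number rose. Going back from 2-bromophenyl to another 4-substituted phenyl, here 4-chlorophenyl, is expected to undo part of that rise. The step from compound 2 to compound 3 is expected to be an at least 2.2-fold lower number from compound 2 to compound 3 (0.34 log units; beyond the scatter), with a real chance that compound 3 again reaches only the limit. Compound 3 is expected to give 45000 nM in this assay, within 15000 nM to 150000 nM.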

Compound 3, half-maximal inhibitory concentration: > 100000 nM
Compound 3: only a limit was reported (the forecaster's own chance of this, stated with the estimate: 40%); middle value at least 2.2-fold (0.34 log units) from the limit.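

In this assay compound 3 gives > 100000 nM, which is a limit of the assay and not a number. Chloro in place of nitro on an aromatic carbon gives an at least 5.1-fold higher number from compound 1 to compound 3 (0.71 log units; beyond the scatter), so 4-chlorophenyl, like 2-bromophenyl, does not retain the value of the 4-nitrophenyl of compound 1, and this change alone is enough for a loss beyond the scatter. The step between compound 2 and compound 3 cannot be read, and the series now rests largely on a single limit: the limit of > 100000 nM in this assay, at which 2 of the 3 values shown sit.

Among the compounds shown, only compound 1 gives a number, so nitro stands alone and no trend among the substituents can be drawn. From the compounds shown here alone, whether a nitrile, an amine or a carboxylic acid on that aromatic carbon would also give a number remains open.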